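The source may report more compounds than this note shows. Statements on the series, on what has been measured and on what is new or still open speak of the compounds shown alone.

Measured compounds in a functional assay on CHO cells with metabotropic glutamate receptor 2 (Homo sapiens) as the target, read by GTPgammaS binding; a higher number here means that more compound is needed for the effect, a lower number that less compound is needed:
Compound 1 `N#Cc1c(-c2ccc(Oc3ccccc3)cc2)ccn2c(CC(F)(F)F)cnc12` gives 186 nM.
Compound 2 `Cc1cc(C)nc(N2CCN(c3ccn4c(CC(F)(F)F)cnc4c3C#N)CC2)n1` gives 447 nM.
Compound 3 `N#Cc1c(N2CCN(c3ncccn3)CC2)ccn2c(CC(F)(F)F)cnc12` gives 851 nM.

Compound 2 has the second highest of the three numbers in this assay. Its nearest neighbour is compound 3, reached by a 1.9-fold higher number from compound 2 to compound 3 (0.28 log units; within the scatter), a step that only swaps the group on an amine nitrogen in a ring. Compound 1 sits furthest away, with a lower number than compound 2, a gap that lies beyond the scatter; these two compounds differ in more than one place, so only their two values can be compared.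

Compound 4 `CCc1cnc2c(C#N)c(N3CCN(c4nc(C)cc(C)n4)CC3)ccn12` is not yet measured. It differs from compound 2 by methyl in place of trifluoromethyl on a saturated chain carbon bound to an aromatic carbon. Within the data shown here, no measured step touches this part of the shared core: the single step, a 1.9-fold higher number from compound 2 to compound 3 (0.28 log units; within the scatter), alters a different group and sits within the scatter. There is thus no basis in these data for a step beyond the scatter in either direction. Compound 4 is expected to give about 450 nM, within 150 nM to 1400 nM. For compound 4 this estimate corresponds to a 1.0-fold higher number from compound 2 to compound 4 (0.00 log units; within the scatter).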

Compound 4, half-maximal effective concentration: 2290 nM
For compound 4 the middle estimate is 5.1-fold (0.71 log units) below the measured one, and the stated range ends below it.
By their numbers in this assay, from the lowest: compound 1; then compounds 2 and 3 (each within the scatter of the next); then compound 4.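

Read in this assay, replacing trifluoromethyl with methyl on a saturated chain carbon bound to an aromatic carbon gives a 5.1-fold higher number from compound 2 to compound 4 (0.71 log units; beyond the scatter), so more compound is needed once the fluorines are gone. This is the first single-place change shown that moves the number beyond the scatter, and it marks this part of the shared core as one where the choice of group counts, at least for this one pair. The compounds shown offer no measurement that could explain the step.

From the compounds shown here alone, whether 2,2,2-trifluoroethyl would also beat ethyl with the other groups of compound 1 or compound 3 in place remains open. So does the place of a longer chain such as propyl, or of a chain ending in an amine, relative to these two compounds.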